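The source may hold more compounds than are shown below. What is called first, only, known or untested is meant among the compounds shown, and "the series" means these compounds.

Measured in a functional assay on Vero cells (Chlorocebus sabaeus) for cytotoxicity; a higher number here means that more compound is tolerated, a lower number that less compound is tolerated:
compound 1, `CCCCCCCCOC(=O)C(O)Cn1cnc2c(N)ncnc21`: 200 ug/mL
compound 2, `CCCOC(=O)C(O)Cn1cnc2c(N)ncnc21`: > 400 ug/mL (a limit)
compound 3, `CC(C)CCOC(=O)C(O)Cn1cnc2c(N)ncnc21`: 400 ug/mL

Compound 3 holds the highest of the two numbers in this assay; compound 1 is nearest, and a 2.0-fold higher number from compound 1 to compound 3 (0.30 log units; within the scatter) lies within the scatter. Compound 2 reached only the limit of this assay (the limit of > 400 ug/mL in this assay, at which 1 of the 3 values shown sits). Compound 4 is `Nc1ncnc2c1ncn2CC(O)C(=O)OCc1ccco1`; it differs from compound 3 by furan-2-yl in place of isobutyl on a saturated chain carbon bound to an oxygen next to a carbonyl group. The steps seen so far bear on it only loosely: a 2.0-fold higher number from compound 1 to compound 3 (0.30 log units; within the scatter) and an at least 2.0-fold higher number from compound 1 to compound 2 (0.30 log units; that floor lies within the scatter) change the chain on the saturated chain carbon bound to the oxygen next to the carbonyl group, and a number no higher from compound 2 to compound 3 (the limit leaves the size open) gives no readable size. None of the steps exceeds the scatter, and none of compound 1, compound 2 or compound 3 carries a ring in that position. The step of no change at the digits printed from compound 3 to compound 4 (within the scatter) is therefore expected to stay within the scatter. Compound 4 is estimated at 400 ug/mL, between 200 ug/mL and 800 ug/mL.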

Compound 4, minimum cytotoxic concentration: 40 ug/mL
Compound 4: middle estimate off by 10-fold (1.00 log units), on the high side, and the stated range ends above it.
By their numbers in this assay, from the lowest: compound 4; then compounds 1 and 3 (each within the scatter of the next).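

Furan-2-yl on this saturated chain carbon gives the first step beyond the scatter in this assay, with a 10-fold lower number from compound 3 to compound 4 (1.00 log units; beyond the scatter) and with a 5.0-fold lower number from compound 1 to compound 4 (0.70 log units; beyond the scatter), so the number falls against both the isobutyl and the heptyl chain. Against ethyl the step is only a floor, an at least 10-fold lower number from compound 2 to compound 4 (1.00 log units; beyond the scatter), and its size stays open. Compound 2 stands at a limit: the limit of > 400 ug/mL in this assay, at which 1 of the 4 values shown sits.

Open, from the compounds shown here alone, is whether the aromatic ring as such or its ring oxygen goes with the lower number. A phenyl, a thiophene or a saturated tetrahydrofuran ring on the same carbon would separate the two.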